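Aryl swap on the thiophene-bearing trimethoxybenzoyl series

The compounds below may be only part of what the source reports. "The series", "measured", "known", "first", "only" and "open" are said of these compounds alone.

Compound 1 `COc1cc(C(=O)c2sc(-c3cccs3)cc2N)cc(OC)c1OC` and compound 2 `COc1cc(C(=O)c2sc(-c3ccccc3Cl)cc2N)cc(OC)c1OC` share the same core and differ only in the aryl group attached beside the ring sulfur. In a functional assay on FM3A cells (Mus musculus) for antiproliferative activity (a lower number here means a stronger inhibitor, a higher number a weaker inhibitor), compound 1 gives 1.7 nM, whereas compound 2 gives 34 nM; the step of a 20-fold higher number from compound 1 to compound 2 (1.30 log units; beyond the scatter) is the only one measured so far, and it leaves compound 2 as the higher of the two numbers in this assay, with compound 1 as its nearest neighbour.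

Compound 3 `COc1cccc(-c2cc(N)c(C(=O)c3cc(OC)c(OC)c(OC)c3)s2)c1` is the next untested member. Its change from compound 2 is 3-methoxyphenyl in place of 2-chlorophenyl on an aromatic carbon. Among the compounds with values here, no measured step covers a change of this kind; the one step known, from thiophen-2-yl to 2-chlorophenyl, shows only that this position is sensitive to the aryl group and that large swings are possible. With a six-membered carbocyclic ring kept and one acceptor entering, the direction is uncertain. Compound 3 is expected to give a moderately lower number than compound 2, estimated as 10 nM with a range of 2 nM to 60 nM, which would mean a step of a 3.4-fold lower number from compound 2 to compound 3 (0.53 log units; beyond the scatter) in this assay.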

Compound 3, half-maximal inhibitory concentration: 36 nM
Beside the measured number, compound 3's estimate is 3.6-fold (0.56 log units) below it, and the stated range covers the measured number.
By their numbers in this assay, from the lowest: compound 1; then compounds 2 and 3 (each within the scatter of the next).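

In this assay, replacing 2-chlorophenyl with 3-methoxyphenyl gives a 1.1-fold higher number from compound 2 to compound 3 (0.02 log units; within the scatter) at this position next to the ring sulfur, so the two substituted phenyl groups are not separated here even though both the substituent and its place on the ring differ. The large step seen earlier is therefore not specific to 2-chlorophenyl: 3-methoxyphenyl in place of thiophen-2-yl gives a 21-fold higher number from compound 1 to compound 3 (1.33 log units; beyond the scatter) and stands with a 20-fold higher number from compound 1 to compound 2 (1.30 log units; beyond the scatter) as a second large step, leaving thiophen-2-yl as the group with the lowest number among these three compounds. Nothing available bears on why the numbers fall this way.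

The compounds shown leave open whether the gap to compound 1 follows from the thiophene ring itself or from the substituents carried by the two phenyl rings, a question that unsubstituted phenyl, thiophen-3-yl or furan-2-yl at this position would address. They also leave open whether the agreement between compound 2 and compound 3 would hold for 3-chlorophenyl, 2-methoxyphenyl or 4-methoxyphenyl, or for a phenyl ring bearing an amine or a carboxylic acid.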